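The source may hold more compounds than are shown below. What is called first, only, known or untested is meant among the compounds shown, and "the series" means these compounds.

Compound 1 `C/C(=N\OCC(=O)O)c1cccc(Cl)c1` and compound 2 `C/C(=N\OCC(=O)O)c1ccc(C2CC2)cc1` share a core and differ only in the group on the ring. In a functional assay on the whole organism for inhibition, with Rattus norvegicus as the target, read by paw edema, with stated times of 1 h and 3 h, at a dose of 50 mg/kg by the oral route (a lower number here means less inhibition, a higher number more inhibition at the dose given (going by the name of the read-out)), compound 1 gives 20%. For compound 2 the assay reports only a limit, < 20%, so compound 2 stands at the floor of the numbers shown (the limit of < 20% in this assay, at which 1 of the 2 values shown sits). Compound 3 `C/C(=N\OCC(=O)O)c1ccc(N)cc1` is not yet measured; it differs from compound 2 by amino in place of cyclopropyl on an aromatic carbon. Among the measured compounds shown here, no measured step guides this change, so the step expected in this assay is none beyond the scatter, written as a step that the limit leaves unreadable from compound 2 to compound 3. Compound 3 is expected to give about 15%, within 0% to 30%.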

Compound 3, a percentage reported as inhibition, in the whole organism at one dose (the size of the read-out at that dose, not a potency): 20%
Compound 3: middle estimate off by 5 percentage points, on the low side; measured number inside the range.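

Putting amino in place of cyclopropyl on the aromatic carbon gives, in this assay, a number no lower from compound 2 to compound 3 (the limit leaves the size open). This is the only step shown at this position, and it shows that the carbon ring of cyclopropyl can give way to a hydrogen-bond donor without the number dropping. Its size stays unreadable because compound 2 carries only a limit: the limit of < 20% in this assay, at which 1 of the 3 values shown sits.

From the compounds shown here alone, whether a carboxylic acid or a longer chain on this carbon would lift the inhibition beyond the usual scatter stays open.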